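Adding a Methyl Group to a Ring Nitrogen

The compounds below may be only part of what the source reports. "The series", "measured", "known", "first", "only" and "open" are said of these compounds alone.

All three measured compounds were tested in a functional assay on CCRF-CEM cells for agonist activity at C-X-C chemokine receptor type 4 (Homo sapiens), read by calcium flux, with a stated time of 25 min; a lower number here means that less compound is needed, a higher number that more compound is needed for the effect. Compound 1 `CCCN(C[C@H]1Cc2c(cccc2N2CCNCC2)CN1)[C@H]1CCCc2cccnc21` gives > 30000 nM in this assay, which is a limit of the measurement rather than a number. Compound 2 `c1cnc2c(c1)CCC[C@@H]2N(CC1CC1)C[C@H]1Cc2c(cccc2N2CCNCC2)CN1` likewise gives > 30000 nM, again a limit. The step that the two limits leave unreadable from compound 1 to compound 2 therefore cannot be sized. Compound 3 `C[C@@H]1CN(c2cccc3c2C[C@H](CN(C)[C@H]2CCCc4cccnc42)NC3)C[C@H](C)N1` gives > 30000 nM, also a limit. Every measured value thus sits at the limit of > 30000 nM in this assay, at which 3 of the 3 values shown sit, and compound 3 is not separated from the others by any readable amount.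

Compound 4 `C[C@@H]1CN(c2cccc3c2C[C@H](CN(C)[C@H]2CCCc4cccnc42)NC3)C[C@H](C)N1C` differs from compound 3 by methyl in place of hydrogen on an amine nitrogen in a ring. For the measured compounds named here, no measured step covers a change of this kind, and the only step recorded at all is itself unreadable, so the measured compounds point to neither a gain nor a loss in this assay. Compound 4 is consequently expected to stay at the limit, with an estimated step that the limit leaves unreadable from compound 3 to compound 4 that cannot be told apart from none. Compound 4 is expected to give about 40000 nM in this assay, within a range of 10000 nM to 150000 nM, and most likely the result will again be reported only as a limit.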

Compound 4, half-maximal effective concentration: > 30000 nM
Compound 4: a limit, no number; the forecaster's own chance of this, stated with the estimate: 80%; the middle value is on the limit's open side.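

In this assay compound 4 gives > 30000 nM, which is a limit and not a number. Compound 3 also stands at a limit, so no step can be read between compound 3 and compound 4. The compounds shown leave open whether any of these changes alters the effect at all, as every result sits together: the limit of > 30000 nM in this assay, at which 4 of the 4 values shown sit.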